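The compounds below may be only part of what the source reports. "The series", "measured", "known", "first", "only" and "open" are said of these compounds alone.

Measured in an ADME assay on Vero 76 cells (Chlorocebus sabaeus) for cytotoxicity, read by MTT assay, with a stated time of 96 h; on this read-out higher numbers stand for lower toxicity in this test and lower numbers for higher toxicity in this test:
Compound 1 `Cc1cccc(C2CC(c3ccc(Oc4ccccc4)cc3)=NN2c2ccc(S(N)(=O)=O)cc2)c1`: 81000 nM
Compound 2 `Cc1ccccc1C1CC(c2ccc(Oc3ccccc3)cc2)=NN1c1ccc(S(N)(=O)=O)cc1`: 90000 nM

Within the data shown here, only these two compounds have numbers so far. Compound 2 stands within the scatter of compound 1, so neither can be placed ahead of the other. The next compound, compound 3 `NS(=O)(=O)c1ccc(N2N=C(c3ccc(Oc4ccccc4)cc3)CC2c2ccccc2F)cc1`, keeps the rest of compound 2 and alters one group: fluoro in place of methyl on an aromatic carbon. In words, this is fluoro in place of methyl on an aromatic carbon, turning 2-methylphenyl into 2-fluorophenyl. Among the measured compounds shown here, no measured step covers this exchange directly. The only one that bears on it is a 1.1-fold higher number from compound 1 to compound 2 (0.05 log units; within the scatter), a change within the methylphenyl group, and it stayed within the scatter. That single step hints that this assay responds little to a small change on this ring, although two compounds are thin evidence and neither carries fluoro. No step beyond the scatter is therefore expected. The expected change is a 1.1-fold lower number from compound 2 to compound 3 (0.05 log units; within the scatter). For compound 3 the expected value is 80000 nM, with an estimated range from 45000 nM to 130000 nM.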

Compound 3, half-maximal cytotoxic concentration: 96000 nM
Estimate against measurement, compound 3: 1.2-fold (0.08 log units) below, and the stated range covers the measured number.
By their numbers in this assay, from the lowest: compounds 1, 2 and 3 (each within the scatter of the next).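

In this assay, fluoro in place of methyl on an aromatic carbon, ortho to a large group, gives a 1.1-fold higher number from compound 2 to compound 3 (0.03 log units; within the scatter) and stays within the scatter. Among these compounds, this is the first exchange of one group for a different group at this place, since compound 1 and compound 2 differ only in where the methyl sits, and the test still does not separate the two compounds. Taking 2-fluorophenyl in place of 3-methylphenyl gives a 1.2-fold higher number from compound 1 to compound 3 (0.07 log units; within the scatter) and is also within the scatter, so all three compounds now form one group with no order among them, though nothing shown offers a reason for this.

Methyl and fluoro each bring a single heavy atom, so it remains open whether this ring would tolerate something larger or very different, such as an amine, a carboxylic acid or a longer chain, with the same lack of response. The three compounds also share the rest of the core, so they say nothing about how changes elsewhere in the molecule would affect the number in this assay.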